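Changing the amide aryl group in a paw edema series

A few compounds are considered here, and "the series" means these few. Any claim that something is new, unique, unknown or untested is made for them only; others in the source may bear on it.

Measured so far:
compound 1, `Cc1ccc(NC(=O)c2c(O)c3cccnc3n(-c3ccccc3)c2=O)cc1`: -3.5%
compound 2, `O=C(Nc1cccc(Cl)c1)c1c(O)c2cccnc2n(-c2ccccc2)c1=O`: 7.6%
compound 3, `O=C(Nc1cccnc1)c1c(O)c2cccnc2n(-c2ccccc2)c1=O`: 30.3%

In a functional assay on the whole organism for inhibition, with Rattus norvegicus as the target, read by paw edema, at a dose of 100 mg/kg by the oral route (on this read-out lower numbers stand for less inhibition and higher numbers for more inhibition at the one dose given (going by the name of the read-out)), compound 1 gives -3.5%, the lowest of the three numbers. The nearest is compound 2 at 7.6%, and the furthest is compound 3 at 30.3%. Both gaps lie beyond the scatter: a number 11.1 percentage points higher from compound 1 to compound 2 (beyond the scatter) is a modest step, and a number 33.8 percentage points higher from compound 1 to compound 3 (beyond the scatter) is a large one. Between the two, a number 22.7 percentage points higher from compound 2 to compound 3 (beyond the scatter) is again modest.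

Compound 4, `O=C(Nc1ccc(Cl)nc1)c1c(O)c2cccnc2n(-c2ccccc2)c1=O`, has not yet been measured. It differs from compound 1 in one place: 6-chloropyridin-3-yl in place of 4-methylphenyl on an amide-type nitrogen. The group that enters combines the ring nitrogen seen in compound 3 with a chlorine atom as seen in compound 2, though at a different place on the ring than in compound 2, so neither measured step matches it exactly. Since the pyridin-3-yl of compound 3 gave a number 33.8 percentage points higher from compound 1 to compound 3 (beyond the scatter) and the chlorinated ring of compound 2 gave a number 11.1 percentage points higher from compound 1 to compound 2 (beyond the scatter), an upward step beyond the scatter is expected, though a number lower than that of compound 3 cannot be ruled out. The expected step is a number 28.5 percentage points higher from compound 1 to compound 4 (beyond the scatter). Compound 4 is thus estimated at 25%, with a range from 5% to 45%.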

Compound 4, a percentage reported as inhibition, in the whole organism at one dose (the size of the read-out at that dose, not a potency): 9.2%
Compound 4: middle estimate off by 15.8 percentage points, on the high side, within the range that was stated.
By their numbers in this assay, from the lowest: compound 1; then compounds 2 and 4 (each within the scatter of the next); then compound 3.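

In this assay chloro in place of hydrogen on an aromatic carbon of the pyridin-3-yl ring gives a number 21.1 percentage points lower from compound 3 to compound 4 (beyond the scatter), so at this position on the amide-type nitrogen the gain seen with the ring nitrogen of compound 3 does not survive the added chlorine in full, and the two changes do not simply add up. The 6-chloropyridin-3-yl group still gives a number 12.7 percentage points higher from compound 1 to compound 4 (beyond the scatter), but against the 3-chlorophenyl group it gives a number 1.6 percentage points higher from compound 2 to compound 4 (within the scatter), which is within the scatter, so the two chlorine-bearing rings cannot be told apart even though only one of them holds a ring nitrogen. Nothing available explains why the added chlorine goes with the lower number.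

The compounds shown leave open whether an amino or methoxy group in place of the chlorine of compound 4 would go with a similar drop, and whether a pyridin-4-yl group would match the pyridin-3-yl group. On these data alone, each number also stands for a single oral dose, so how these compounds would rank at other doses remains unknown.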